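This account rests on a few compounds, and the source may have more. Where it says the series, first, only, none or still open, it means among the compounds named here.

In an ADME assay on BaF3 cells (Mus musculus) for cytotoxicity, read by CellTiter-Glo and CCK-8 assay, with a stated time of 72 h (a lower number here means a stronger inhibitor of growth, a higher number a weaker inhibitor of growth), compound 1 `C=CC(=O)NCc1ccc(C(=O)Nc2ccc(C)c(Nc3nccc(-c4cccnc4)n3)c2)cc1` reads > 10000 nM, which is a limit and not a number. Compound 2 `CCC(=O)NCc1cccc(C(=O)Nc2ccc(C)c(Nc3nccc(-c4cccnc4)n3)c2)c1` gives 4750 nM and compound 3 `Cc1ccc(NC(=O)c2ccc(CNC(=O)c3cccnc3)c(C(F)(F)F)c2)cc1Nc1nccc(-c2cccnc2)n1` gives 8330 nM. These two values lie within the scatter of each other, so compound 2 stands level with compound 3. Compound 4 `C=CC(=O)Nc1cccc(C(=O)Nc2ccc(C)c(Nc3nccc(-c4cccnc4)n3)c2)c1` differs from compound 2 as follows: (vinylcarbonyl)amino in place of (propanoylamino)methyl on an aromatic carbon. It carries (vinylcarbonyl)amino in place of (propanoylamino)methyl on an aromatic carbon. Among the measured compounds shown here, no measured pair isolates this change, so no shift beyond the scatter is expected in this assay, and compound 2 at 4750 nM serves as the anchor. The expected change is a 1.2-fold higher number from compound 2 to compound 4 (0.06 log units; within the scatter). For compound 4 the estimated value is 5500 nM, with an expected range of 2200 nM to 12000 nM.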

Compound 4, concentration for 50% growth inhibition: 2480 nM
The estimate for compound 4 lay 2.2-fold (0.35 log units) above the measured number, and the stated range covers the measured number.
By their numbers in this assay, from the lowest: compounds 4, 2 and 3 (each within the scatter of the next, the first and the last beyond it). At a limit, above all of these: compound 1.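

In this assay, placing (vinylcarbonyl)amino in place of (propanoylamino)methyl on this aromatic carbon, meta to a large group, gives a 1.9-fold lower number from compound 2 to compound 4 (0.28 log units; within the scatter), so this exchange does not separate the two compounds. The change alters the link to the ring and the acyl end together, and this single step cannot tell their contributions apart. Nothing available bears on a cause for this step.

Open, from the compounds shown here alone, is whether a propanoylamino group set directly on this carbon would read like compound 4. Also open, going by these compounds, is whether an amine or a longer chain here would move the number beyond the scatter.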